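A few compounds are considered here, and "the series" means these few. Any claim that something is new, unique, unknown or untested is made for them only; others in the source may bear on it.

Measured compounds in a functional assay on MCF7 cells (Homo sapiens) for cytotoxicity, read by neutral red uptake, with a stated time of 3 days; a lower number here means a stronger inhibitor, a higher number a weaker inhibitor:
- compound 1 `Nc1ccc(-c2cc(=O)c3c(N)c(F)c(Br)c(F)c3o2)cc1F`: 160 nM
- compound 2 `CCOC(=O)c1c(F)c(N)c2c(=O)cc(-c3ccc(N)c(F)c3)oc2c1F`: 1400 nM
- compound 3 `CN(C)CCC(=O)OCc1c(F)c(N)c2c(=O)cc(-c3ccc(N)c(F)c3)oc2c1F`: 19 nM

Compound 1 stands second highest of the three numbers. Its nearest neighbour is compound 3, which gives a lower number, an 8.4-fold lower number from compound 1 to compound 3 (0.93 log units; beyond the scatter); the furthest is compound 2, which gives a higher number, an 8.8-fold higher number from compound 1 to compound 2 (0.94 log units; beyond the scatter). Between the two substituted analogues the gap is large, a 74-fold lower number from compound 2 to compound 3 (1.87 log units; beyond the scatter).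

The unmeasured compound 4 `CCCOCc1c(F)c(N)c2c(=O)cc(-c3ccc(N)c(F)c3)oc2c1F` differs from compound 1 at the same position that varies across the series: propoxymethyl in place of bromo on an aromatic carbon. Both recorded steps bear on it, since each also replaces the bromo at this carbon, and both are modest but run in opposite directions. The ethoxycarbonyl of compound 2 raised the number; the (((2-(dimethylamino)ethyl)carbonyl)oxy)methyl of compound 3 lowered it. Propoxymethyl shares the oxymethyl attachment with the group in compound 3 but carries none of its ester or amine, so the step is expected to fall short of an 8.4-fold lower number from compound 1 to compound 3 (0.93 log units; beyond the scatter) and to stay nearer compound 1.

For compound 4 in this assay the estimate is 80 nM, within 25 nM to 300 nM, which corresponds to an expected step of a 2.0-fold lower number from compound 1 to compound 4 (0.30 log units; within the scatter).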

Compound 4, half-maximal inhibitory concentration: 1200 nM
For compound 4 the middle estimate is 15-fold (1.18 log units) below the measured one; the whole stated range lies below it.
By their numbers in this assay, from the lowest: compound 3; then compound 1; then compounds 4 and 2 (each within the scatter of the next).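

In this assay, the oxymethyl attachment alone does not go with the low number of compound 3: putting propyl on that oxygen in place of (2-(dimethylamino)ethyl)carbonyl gives a large loss (a 63-fold higher number from compound 3 to compound 4 (1.80 log units; beyond the scatter)), and replacing the bromo with propoxymethyl runs opposite to the earlier expectation (a 7.5-fold higher number from compound 1 to compound 4 (0.88 log units; beyond the scatter)). Propoxymethyl and ethoxycarbonyl on this aromatic carbon cannot be told apart (a 1.2-fold lower number from compound 2 to compound 4 (0.07 log units; within the scatter)), so of the three replacements of bromo, only the group in compound 3 gives a lower number than compound 1, while compounds 2 and 4 go against any general gain from leaving the bromo. No measurement shown here accounts for these steps.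

Going by these compounds, the step between compound 3 and compound 4 changes the dimethylamino group and the ester carbonyl together, so the share of each remains open. A propanoyl ester on the same oxygen, with the carbonyl but no amine, and a 2-(dimethylamino)ethyl ether, with the amine but no carbonyl, would separate the two.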